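GIP receptor series: aryl amine swap from compound 2 to 3

The source may hold more compounds than are shown below. What is called first, only, known or untested is meant among the compounds shown, and "the series" means these compounds.

Measured compounds:
compound 1 `COc1c(Nc2ccc(S(C)(=O)=O)cc2F)ncnc1OC1C[C@@H]2COC[C@@H](C1)N2C(=O)OC1(C)CC1` — 0.427 nM
compound 2 `CC1(OC(=O)N2C[C@H]3COC[C@@H](C2)[C@@H]3Oc2ncnc(Nc3ccc(C#N)cc3Cl)c2F)CC1` — 58 nM

Two compounds carry a number in a functional assay for agonist activity at Glucose-dependent insulinotropic receptor (Mus musculus), read by cAMP accumulation; a higher number here means that more compound is needed for the effect, a lower number that less compound is needed. Compound 2 gives 58 nM, the higher of the two; compound 1 gives 0.427 nM. Within the data shown here, the two differ in several places at once, so no single step links them and the gap says only that compound 2 needs far more compound than compound 1.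

Compound 3 `CC1(OC(=O)N2C[C@H]3COC[C@@H](C2)[C@@H]3Oc2ncnc(Nc3ccccc3F)c2F)CC1` is not yet measured. It follows from compound 2 by one change: 2-fluorophenyl in place of 2-chloro-4-cyanophenyl on a nitrogen on an aromatic ring. Among the measured compounds shown here, the 2-fluorophenyl that enters carries neither the nitrile nor the chlorine that leave, and no measured pair in this set isolates either group.

For the measured compounds named here, with no step of this kind on record, the expectation rests on compound 2 alone. A loss of potency beyond the scatter is expected, so that compound 3 in this assay is estimated at 220 nM, range 40 nM to 1500 nM. The expected step of a 3.8-fold higher number from compound 2 to compound 3 (0.58 log units; beyond the scatter) is an estimate, not a measurement.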

Compound 3, half-maximal effective concentration: 25 nM
Compound 3: the middle estimate sits 8.8-fold (0.94 log units) above what was measured; the whole stated range lies above it.
By their numbers in this assay, from the lowest: compound 1; then compound 3; then compound 2.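

In this assay, among these compounds, replacing 2-chloro-4-cyanophenyl with 2-fluorophenyl on a nitrogen on an aromatic ring gives a 2.3-fold lower number from compound 2 to compound 3 (0.37 log units; beyond the scatter), the first single-place step. On this core, therefore, potency at this position does not depend on the nitrile and the chlorine being present together, and the smaller group, with no hydrogen-bond acceptor, reads slightly better. No measured evidence accounts for the step.

The change removes the nitrile and the chlorine and adds a fluorine in one move, so the contribution of each remains unresolved. Also open, from the compounds shown here alone, is how this position responds to other groups on that nitrogen, such as a plain phenyl, a pyridyl or a 2-fluorophenyl carrying a methoxy group.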